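A few compounds are considered here, and "the series" means these few. Any claim that something is new, unique, unknown or untested is made for them only; others in the source may bear on it.

Three compounds have been measured in a functional assay on U-87MG ATCC cells for inhibition, with U-87 MG (Homo sapiens) as the target, read by MTT assay, with a stated time of 72 h; on this read-out lower numbers stand for stronger inhibition and higher numbers for weaker inhibition:

Compound 1 `Cc1noc(C)c1-c1cnc(N)c(Oc2ccc(C(=O)Nc3ccccc3Cl)cc2)n1`: 60500 nM
Compound 2 `Cc1noc(C)c1-c1cnc(N)c(Oc2ccc(C(=O)Nc3ncccc3Cl)cc2)n1`: 45600 nM
Compound 3 `Cn1cc(-c2cnc(N)c(Oc3ccc(C(=O)Nc4ccccc4Cl)cc3)n2)cn1`: 44800 nM

Compound 3 shows the lowest number of the three in this assay, though its gaps to compound 2 and to compound 1 both lie within the scatter, so no order among them can be read. Compound 4 `Cn1cc(-c2cnc(N)c(Oc3ccc(C(=O)Nc4ccc(Cl)cn4)cc3)n2)cn1` differs from compound 3 by 5-chloropyridin-2-yl in place of 2-chlorophenyl on an amide-type nitrogen. For the measured compounds named here, one measured step bears on this exchange on the amide-type nitrogen: a 1.3-fold lower number from compound 1 to compound 2 (0.12 log units; within the scatter), which stayed within the scatter. Compound 4 is therefore expected to give a number near that of compound 3, with a step of a 1.1-fold lower number from compound 3 to compound 4 (0.05 log units; within the scatter) that is not expected to exceed the scatter. The estimate for compound 4 in this assay is 40000 nM, within a range of 15000 nM to 110000 nM.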

Compound 4, half-maximal inhibitory concentration: 22200 nM
Estimate against measurement, compound 4: 1.8-fold (0.26 log units) above, and the stated range covers the measured number.
By their numbers in this assay, from the lowest: compounds 4, 3, 2 and 1 (each within the scatter of the next, the first and the last beyond it).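

In this assay, placing 5-chloropyridin-2-yl instead of 2-chlorophenyl on the amide-type nitrogen gives a 2.0-fold lower number from compound 3 to compound 4 (0.30 log units; within the scatter). This second exchange to a chloropyridine, made on a compound carrying 1-methyl-1H-pyrazol-4-yl and with a different chloropyridine from that in compound 2, also shows no difference that can be read. No measurement at hand accounts for this step. The compounds shown leave open whether a group without chlorine on that nitrogen, such as an unsubstituted phenyl or a cyclohexyl, would move the number beyond the scatter.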